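Chain shortening on the piperazine amide of the shared core

This account rests on a few compounds, and the source may have more. Where it says the series, first, only, none or still open, it means among the compounds named here.

Measured compounds:
- compound 1, `c1nnc2nnc(N3CCCC3)nn12`: 24400 nM
- compound 2, `OCC(CO)(CO)Nc1nnc2nncn2n1`: > 100000 nM
- compound 3, `CCCCCC(=O)N1CCN(c2nnc3nncn3n2)CC1`: 3610 nM

In a functional assay on HL-60 cells (Homo sapiens) for inhibition, read by MTT assay, with a stated time of 72 h (on this read-out higher numbers stand for weaker inhibition and lower numbers for stronger inhibition), compound 3 gives 3610 nM, the lowest of the two numbers. The nearest number is that of compound 1, which in this assay gives 24400 nM, a gap that lies beyond the scatter. Compound 2 is recorded only as a limit of this assay, > 100000 nM, and not as a number; the limit of > 100000 nM in this assay, at which 1 of the 3 values shown sits, marks this.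

The next compound, compound 4, `CCCCC(=O)N1CCN(c2nnc3nncn3n2)CC1`, remains to be measured. It differs from compound 3 in one place: hydrogen in place of methyl on a saturated chain carbon, four bonds along the chain from a carbonyl carbon. The chain carrying the carbonyl is thus shortened by one carbon at its end, with the amide-bearing ring and the shared core left untouched.

Among the compounds with values here, no step between measured compounds is available for a change of this kind, so the expectation rests on the value of compound 3 alone. Trimming a saturated chain by one carbon is expected to move the number only a little, if at all, and no direction beyond the scatter is assumed. The step from compound 3 to compound 4 is thus estimated as a 1.2-fold higher number from compound 3 to compound 4 (0.10 log units; within the scatter), within the scatter. For compound 4 in this assay a value of 4500 nM is estimated, with a range from 1500 nM to 14000 nM.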

Compound 4, half-maximal inhibitory concentration: 3130 nM
Compound 4: middle estimate off by 1.4-fold (0.16 log units), on the high side; the range from low to high includes it.
By their numbers in this assay, from the lowest: compounds 4 and 3 (each within the scatter of the next); then compound 1. At a limit, above all of these: compound 2.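

In this assay, within the data shown here, the step reads a 1.2-fold lower number from compound 3 to compound 4 (0.06 log units; within the scatter) and is the only step that isolates a single change, here hydrogen in place of methyl on a saturated chain carbon, four bonds along the chain from a carbonyl carbon. The chain end therefore gives up this methyl with no readable change: compound 3 at 3610 nM and compound 4 at 3130 nM form a pair that cannot be ordered, and both keep clear of compound 1 in the ranking printed for this assay. Among these compounds, the one recorded observation on the series concerns a limit reached by another compound and offers no account of this step.

From the compounds shown here alone, the same cut taken further, to a propyl or an ethyl on the carbonyl, remains open, as do a longer chain and a chain ending in an amine or a carboxylic acid, so one step cannot show how far the read-out follows chain length. Among the compounds shown here, compound 1 and compound 2 differ from this pair in more than one place, so they give no step that tells whether the carbonyl or the amide-bearing ring carries the difference from them.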